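The compounds below may be only part of what the source reports. "The series", "measured", "known", "first", "only" and "open" are said of these compounds alone.

Compound 1 `CC(C)=CCCC(C)/C=C/C=C(\C)C=O` — 2.5 ug/mL
Compound 2 `C=C/C(C)=C/C=C/C(C)(O)CCC=C(C)C` — 2.5 ug/mL
Compound 3 `C=C/C(C)=C\C=C\C(C)CC(=O)CC(C)C` — 2.5 ug/mL

In a functional assay on A549 cells (Homo sapiens) for cytotoxicity (on this read-out higher numbers stand for weaker inhibition and lower numbers for stronger inhibition), compound 1 gives 2.5 ug/mL, compound 2 gives 2.5 ug/mL and compound 3 gives 2.5 ug/mL. Compound 3 thus stands level with compounds 1 and 2 at the digits shown, with its nearest neighbour compound 1 and its furthest compound 2 both within the scatter. Compound 4 `C=C/C(C)=C/C=C/C(C)CC(=O)CC(C)C` differs from compound 3 in one respect: the two compounds have the same atoms and bonds; at least one stereo element is drawn with a configuration in one of them and without one in the other: 1 of 3 stereo elements differ; a double bond is drawn Z in compound 3 and E in compound 4. Going by the values given here, no step between measured compounds is available for comparison. Given the even values across all three measured compounds, no step beyond the scatter is expected in this assay. Compound 4 is therefore expected at 2.5 ug/mL, within 1.2 ug/mL to 5 ug/mL. The expected step is no change at the digits printed from compound 3 to compound 4 (within the scatter).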

Compound 4, half-maximal inhibitory concentration: 5 ug/mL
Beside the measured number, compound 4's estimate is 2.0-fold (0.30 log units) below it; low and high end bracket the measured number.
By their numbers in this assay, from the lowest: compounds 1, 2, 3 and 4 (each within the scatter of the next).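

In this assay, going by these compounds alone, this pair gives the first comparison of compounds that differ in one place, a double bond drawn Z in compound 3 and E in compound 4, and the result reads a 2.0-fold higher number from compound 3 to compound 4 (0.30 log units; within the scatter). The drawn geometry of this double bond therefore has no effect that can be told from the scatter. The comparison also carries a caveat about how far the two drawings can be set against each other: the fact that one of compounds 3 and 4 is drawn with a defined configuration and the other without, at the place where they differ.

The compounds shown leave open whether an amine or a carboxylic acid in place of the carbonyl would change the number in this assay.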